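Paw swelling in rats: a benzylamino amide estimate

The compounds below may be only part of what the source reports. "The series", "measured", "known", "first", "only" and "open" are said of these compounds alone.

Of the compounds shown here, two sharing one core have been tested so far. Compound 1 `CCNC(=O)CC1CCc2cc(OC)c(OC)cc21` carries a hydrogen on its amide-type nitrogen, and in a functional assay on the whole organism (strain Wistar) for inhibition, with Rattus norvegicus as the target, read by paw edema, with stated times of 60 min and 6 h, at a dose of 100 mg/kg by the oral route (a higher number here means more inhibition at the dose given (going by the name of the read-out), a lower number less inhibition), compound 1 gives 20.4%. Compound 2 `CCN(CC)C(=O)CC1CCc2cc(OC)c(OC)cc21` has an ethyl on that nitrogen instead, and in this assay compound 2 gives 31.5%. Among the compounds with values here, the single step joining them, a number 11.1 percentage points higher from compound 1 to compound 2 (beyond the scatter), goes with ethyl in place of hydrogen on an amide-type nitrogen. Among the two numbers measured, compound 2 stands highest, with compound 1 the lower one beyond the scatter.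

Compound 3 `COc1cc2c(cc1OC)C(CC(=O)NCc1ccccc1)CC2` is the next candidate. Its change from compound 2 is benzylamino in place of diethylamino on a carbonyl carbon. This is not the same move as the measured step: the benzylamino group brings back one hydrogen-bond donor, as in compound 1, while also adding an aromatic ring that neither measured compound has. Within the data shown here, no measured pair shows what such a ring does here, so the measured step gives only a loose guide. The expected step of a number 3.5 percentage points lower from compound 2 to compound 3 (within the scatter) is estimated to lie within the scatter, leaning slightly downward toward compound 1. Compound 3 is therefore expected to give 28% in this assay, with a range from 10% to 46%.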

Compound 3, a percentage reported as inhibition, in the whole organism at one dose (the size of the read-out at that dose, not a potency): 30.6%
Beside the measured number, compound 3's estimate is 2.6 percentage points below it, within the range that was stated.
By their numbers in this assay, from the lowest: compound 1; then compounds 3 and 2 (each within the scatter of the next).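

In this assay, benzylamino in place of diethylamino on the carbonyl carbon gives a number 0.9 percentage points lower from compound 2 to compound 3 (within the scatter), so a group with a hydrogen-bond donor and an aromatic ring cannot be told apart here from one with neither. Compound 1 also keeps a hydrogen on its amide-type nitrogen, yet phenyl in place of methyl on the saturated chain carbon bound to that nitrogen gives a number 10.2 percentage points higher from compound 1 to compound 3 (beyond the scatter), which shows that among these three compounds, keeping the amide hydrogen does not by itself tie a compound to the lower number of compound 1. Nothing available explains why the two groups read alike or why the phenyl step goes up.

On these data alone, what remains open is whether the aromatic ring needs to sit this close to the nitrogen, which a longer chain such as phenethylamino would test, and whether a ring built into the amine, as in morpholine, would read the same. Also open, as far as these compounds go, is whether a carboxylic acid in place of the amide would keep the inhibition at this level.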